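Working notes: from 3-methylbenzyl to 3,4-dichlorobenzyl

The compounds below may be only part of what the source reports. "The series", "measured", "known", "first", "only" and "open" are said of these compounds alone.

Measured in a functional assay on K562 cells (Homo sapiens) for antiproliferative activity, with a stated time of 72 h; a higher number here means a weaker inhibitor, a lower number a stronger inhibitor:
- compound 1 `OC[C@H]1O[C@@H](n2cnc3c(NCc4cccc(F)c4)ncnc32)[C@H](O)[C@@H]1O`: 7600 nM
- compound 2 `OC[C@H]1O[C@@H](n2cnc3c(NCc4ccc(Br)cc4)ncnc32)[C@H](O)[C@@H]1O`: 68200 nM
- compound 3 `Cc1cccc(CNc2ncnc3c2ncn3[C@@H]2O[C@H](CO)[C@@H](O)[C@H]2O)c1`: > 166000 nM (a limit)

Compound 3 gives only a limit, which is the limit of > 166000 nM in this assay, at which 1 of the 3 values shown sits, and not a number.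

Compound 4 `OC[C@H]1O[C@@H](n2cnc3c(NCc4ccc(Cl)c(Cl)c4)ncnc32)[C@H](O)[C@@H]1O` is still unmeasured. It differs from compound 3 by 3,4-dichlorophenyl in place of 3-methylphenyl on a saturated chain carbon bound to a nitrogen on an aromatic ring on the shared core, the same difference reading 3-methylbenzyl to 3,4-dichlorobenzyl.

For the measured compounds named here, two measured steps bear on this change. Compound 1 carries 3-fluorophenyl, and an at least 21-fold higher number from compound 1 to compound 3 (1.33 log units; beyond the scatter) is large. Compound 2 carries 4-bromophenyl, and an at least 2.4-fold higher number from compound 2 to compound 3 (0.38 log units; beyond the scatter) is at least modest. The step of a 9.0-fold higher number from compound 1 to compound 2 (0.95 log units; beyond the scatter) shows that halogen-bearing compounds can still differ widely.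

Going by the values given here, both halogen-bearing compounds give lower numbers than compound 3, with no compound here going against that, so a step to a lower number is expected in this assay of at least modest size. The expected step is an at least 4.1-fold lower number from compound 3 to compound 4 (0.61 log units; beyond the scatter) in this estimate.

For compound 4 the estimated value is 40000 nM with an expected range from 10000 nM to 140000 nM in this series.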

Compound 4, half-maximal inhibitory concentration: 10800 nM
Compound 4: the middle estimate sits 3.7-fold (0.57 log units) above what was measured, and the stated range covers the measured number.
By their numbers in this assay, from the lowest: compounds 1 and 4 (each within the scatter of the next); then compound 2. At a limit, above all of these: compound 3.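

In this assay, 3,4-dichlorophenyl in place of 3-methylphenyl on a saturated chain carbon bound to a nitrogen on an aromatic ring gives an at least 15-fold lower number from compound 3 to compound 4 (1.18 log units; beyond the scatter), so the size of this step is a minimum. Compound 3 holds a limit and not a number: the limit of > 166000 nM in this assay, at which 1 of the 4 values shown sits.

The series also gains its first comparison of a two-chlorine group with single-halogen groups at this place, with a 6.3-fold lower number from compound 2 to compound 4 (0.80 log units; beyond the scatter), whereas a 1.4-fold higher number from compound 1 to compound 4 (0.15 log units; within the scatter) does not separate those two compounds.

From the compounds shown here alone, how 3-chlorophenyl or 4-chlorophenyl would read against 3,4-dichlorophenyl remains open, so the contribution of each chlorine cannot be assigned. Also open, going by these compounds, is how the series would respond to a phenyl ring carrying an amine or a carboxylic acid at this place.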